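Aryl substituent change from compound 3 to compound 4

This account rests on a few compounds, and the source may have more. Where it says the series, first, only, none or still open, it means among the compounds named here.

Among the compounds with values here, compound 3 `CCOC(=O)C1=C(C)NC(C)=C(C(=O)OCC)C1c1c(-c2ccc(Cl)cc2)nc2sccn12` gives 97 nM in an ADME assay on Left cardiac atrium (Cavia porcellus) (on this read-out lower numbers stand for an effect already at smaller amounts and higher numbers for an effect only at larger amounts of compound), the lowest of the three numbers so far; compound 2 `CCOC(=O)C1=C(C)NC(C)=C(C(=O)OCC)C1c1c(-c2cc(F)c(F)cc2F)nc2sccn12` gives 160 nM, with a 1.6-fold lower number from compound 2 to compound 3 (0.22 log units; within the scatter), and compound 1 `CCOC(=O)C1=C(C)NC(C)=C(C(=O)OCC)C1c1c(-c2ccccc2F)nc2sccn12` gives 5150 nM, with a 53-fold lower number from compound 1 to compound 3 (1.73 log units; beyond the scatter) and a 32-fold lower number from compound 1 to compound 2 (1.51 log units; beyond the scatter). Compound 4 `CCOC(=O)C1=C(C)NC(C)=C(C(=O)OCC)C1c1c(-c2ccc(Br)c([N+](=O)[O-])c2)nc2sccn12` carries 4-bromo-3-nitrophenyl in place of 4-chlorophenyl on an aromatic carbon. The measured steps that bear on this change all alter the pendant phenyl ring: the two large steps from compound 1 show that the substitution pattern can shift the number strongly, whereas the step from compound 2 to compound 3 shows two differently substituted rings within the scatter. Within the data shown here, no measured step involves 4-bromo-3-nitrophenyl, so for compound 4 a step not beyond the scatter is expected, a 1.9-fold higher number from compound 3 to compound 4 (0.27 log units; within the scatter). Compound 4 is estimated at 180 nM, range 50 nM to 650 nM.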

Compound 4, half-maximal effective concentration: 1270 nM
The estimate for compound 4 lay 7.1-fold (0.85 log units) below the measured number; the whole stated range lies below it.
By their numbers in this assay, from the lowest: compounds 3 and 2 (each within the scatter of the next); then compound 4; then compound 1.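

In this assay, the 4-bromo-3-nitrophenyl group separates from the two rings that sat within the scatter of each other: there is a 13-fold higher number from compound 3 to compound 4 (1.12 log units; beyond the scatter) and a 7.9-fold higher number from compound 2 to compound 4 (0.90 log units; beyond the scatter) on this aromatic carbon. The change is not the worst seen at this position, since there is still a 4.1-fold lower number from compound 1 to compound 4 (0.61 log units; beyond the scatter) for the 2-fluorophenyl group. No measured evidence bears on the reason for these steps. The compounds shown do not separate the bromine from the nitro group, so neither can be assigned the rise. On these data alone, how an amine or a carboxylic acid in place of the nitro group would read remains open.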